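Replacing the oxan-4-yl group of compound 3

This account rests on a few compounds, and the source may have more. Where it says the series, first, only, none or still open, it means among the compounds named here.

In a physicochemical assay for lipophilicity, at pH 7.4 (a lower number here means a more polar compound, a higher number a more lipophilic compound), compound 1 `COc1ccc2c(c1)C=CN(C)C(=O)[C@@H]2C` gives 4.3, compound 2 `CCc1ccc2c(c1)C=CN(C)C(=O)[C@@H]2C` gives 5.9, and compound 3 `C[C@H]1C(=O)N(C)C=Cc2cc(CC3CCOCC3)ccc21` gives 5.4, the second highest of the three numbers. Compound 4 `C[C@H]1C(=O)N(C)C=Cc2cc(CCO)ccc21` carries hydroxymethyl in place of oxan-4-yl on a saturated chain carbon bound to an aromatic carbon. Within the data shown here, the closest precedent is the modest a number 0.50 log units lower from compound 2 to compound 3 (beyond the scatter), which changes the group at this same place. Among the measured compounds shown here, the large a number 1.10 log units higher from compound 1 to compound 3 (beyond the scatter) and the large a number 1.60 log units higher from compound 1 to compound 2 (beyond the scatter) show how far this series can move, though no measured compound holds hydroxymethyl. A large fall is therefore expected, with an estimated a number 1.20 log units lower from compound 3 to compound 4 (beyond the scatter). In this assay, compound 4 is estimated at 4.2, within an expected range of 3.6 to 4.8.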

Compound 4, distribution coefficient: 2.6
Beside the measured number, compound 4's estimate is 1.60 log units above it; measured number below the stated range.
By their numbers in this assay, from the lowest: compound 4; then compound 1; then compound 3; then compound 2.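

In this assay, among these compounds, a hydroxy on the ethyl group of compound 2 gives a number 3.30 log units lower from compound 2 to compound 4 (beyond the scatter) and is a larger step than any seen among the earlier compounds. Hydroxymethyl in place of oxan-4-yl gives a number 2.80 log units lower from compound 3 to compound 4 (beyond the scatter) and 2-hydroxyethyl in place of methoxy gives a number 1.70 log units lower from compound 1 to compound 4 (beyond the scatter) so that compound 4 now holds the lowest number in the series. No evidence at hand accounts for the size of these steps. From the compounds shown here alone, whether a 2-methoxyethyl chain, an amine or a carboxylic acid at this place would fall as far remains open. So does whether a longer chain ending in hydroxy would give a number nearer that of compound 2 or that of compound 4.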